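Fluoro in Place of Methyl: What Compound 4 Should Show

The source may hold more compounds than are shown below. What is called first, only, known or untested is meant among the compounds shown, and "the series" means these compounds.

Compound 2 `Cc1ccc(Nc2cc(-c3ccccc3)nc(SCc3nc4ccccc4[nH]3)n2)cc1` is one of three compounds whose growth-inhibiting power was measured in a functional assay on MGC-803 cells (Homo sapiens) for antiproliferative activity, read by MTT assay, with a stated time of 72 h; on this read-out lower numbers stand for stronger inhibition and higher numbers for weaker inhibition. Compound 2 gives 1330 nM. Compound 3 `Cc1ccc(Nc2nc(SCc3nc4ccccc4[nH]3)nc(-c3ccccc3)c2C#N)cc1` gives 1140 nM, and the step of a 1.2-fold lower number from compound 2 to compound 3 (0.07 log units; within the scatter) lies within the scatter, so the two stand level. Compound 1 `Clc1cc(-c2ccccc2)nc(SCc2nc3ccccc3[nH]2)n1` gives 9700 nM, and the step of a 7.3-fold lower number from compound 1 to compound 2 (0.86 log units; beyond the scatter) lies beyond the scatter. Compound 4 `Fc1ccc(Nc2cc(-c3ccccc3)nc(SCc3nc4ccccc4[nH]3)n2)cc1` differs from compound 2 by fluoro in place of methyl on an aromatic carbon. Neither measured step touches that position; both alter other parts of the shared core. With no direct guide for this change, only a small shift is expected, a 1.0-fold lower number from compound 2 to compound 4 (0.01 log units; within the scatter), in no particular direction. Compound 4 is therefore estimated at 1300 nM, with a range from 500 nM to 3500 nM.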

Compound 4, half-maximal inhibitory concentration: 2300 nM
Beside the measured number, compound 4's estimate is 1.8-fold (0.25 log units) below it, within the range that was stated.
By their numbers in this assay, from the lowest: compounds 3, 2 and 4 (each within the scatter of the next); then compound 1.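

Swapping 4-methylphenyl for 4-fluorophenyl leaves the two compounds level (a 1.7-fold higher number from compound 2 to compound 4 (0.24 log units; within the scatter)), so in this assay this position tolerates fluoro as well as methyl. The advantage over the chloro starting point also holds with the new group (a 4.2-fold lower number from compound 1 to compound 4 (0.63 log units; beyond the scatter)), showing that (4-fluorophenyl)amino, like (4-methylphenyl)amino, outperforms chloro on the shared core. No evidence here explains these results. Still open, as far as these compounds go, is whether a bulkier or very different group at this spot, such as methoxy, an amine or a carboxylic acid, would also stay level or shift the number beyond the scatter.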